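Solubility notes: one extra carbon on compound 1

The source may hold more compounds than are shown below. What is called first, only, known or untested is meant among the compounds shown, and "the series" means these compounds.

- compound 1 `CC(C)C(c1ccc(-c2ccc3cccc(F)c3c2)[nH]c1=O)C1NC(=O)NC1=O`: 5800 nM
- compound 2 `CCC(CC)C(/C=C1\OC(=O)NC1=O)c1ccc(-c2ccc3cccc(F)c3c2)[nH]c1=O`: 3680 nM
- compound 3 `CC(C)[C@H](C[C@H]1OC(=O)NC1=O)c1ccc(-c2ccc3cccc(F)c3c2)[nH]c1=O`: 24400 nM

In a physicochemical assay for solubility, measured as kinetic solubility, at pH 2 (on this read-out lower numbers stand for lower solubility and higher numbers for higher solubility), compound 1, at 5800 nM, lies within the scatter of compound 2, at 3680 nM. The same compound 1 lies below compound 3, at 24400 nM, by a gap beyond the scatter.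

The next compound is compound 4 `CC(C)C(CC1NC(=O)NC1=O)c1ccc(-c2ccc3cccc(F)c3c2)[nH]c1=O`, still unmeasured in this assay. It differs from compound 1 as follows: (2,5-dioxoimidazolidin-4-yl)methyl in place of 2,5-dioxoimidazolidin-4-yl on a saturated chain carbon bound to an aromatic carbon and a saturated chain carbon. The hydantoin-type ring name stays the same in both groups, and (2,5-dioxoimidazolidin-4-yl)methyl now stands in place of 2,5-dioxoimidazolidin-4-yl on the saturated chain carbon.

Going by the values given here, no measured pair shows this change, so any expectation is loose. A small rise is expected, and it may not exceed the scatter, with compound 3 at 24400 nM pulling the guess upward. The expected move is a 1.6-fold higher number from compound 1 to compound 4 (0.19 log units; within the scatter). For compound 4 the estimated value is 9000 nM, with an expected range of 3500 nM to 25000 nM.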

Compound 4, solubility: 13000 nM
Beside the measured number, compound 4's estimate is 1.4-fold (0.16 log units) below it; the measured number falls inside the stated range.
By their numbers in this assay, from the lowest: compounds 2 and 1 (each within the scatter of the next); then compounds 4 and 3 (each within the scatter of the next).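

In this assay, the series now has its first step at this position that changes one place only: (2,5-dioxoimidazolidin-4-yl)methyl in place of 2,5-dioxoimidazolidin-4-yl on a saturated chain carbon bound to an aromatic carbon and a saturated chain carbon gives a 2.2-fold higher number from compound 1 to compound 4 (0.35 log units; beyond the scatter) as a modest move. The two groups share the same ring and the same counts of hydrogen-bond donors and acceptors, and differ in carbon count, 4 against 3, so a change this small at this position is enough to move the number past the scatter. Nothing available explains the move.

This single pair cannot show whether a longer chain to the same ring would extend the rise. It also leaves open what a carboxylic acid or an amine would give in place of the ring at this position.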